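This account rests on a few compounds, and the source may have more. Where it says the series, first, only, none or still open, it means among the compounds named here.

Measured compounds, with their values in a functional assay on C-33-A cells (Homo sapiens) for antiproliferative activity, read by MTT assay; on this read-out lower numbers stand for stronger inhibition and higher numbers for weaker inhibition:

compound 1, `COc1ccc(-c2nc(N3CCNCC3)nc3ccccc23)c(OC)c1`: 50 ug/mL
compound 2, `c1ccc2c(c1)ccn2-c1nc(N2CCNCC2)nc2ccccc12`: 8.2 ug/mL
compound 3, `CN1CCN(c2nc(-c3cn(C)c4ccccc34)c3ccccc3n2)CC1`: 50 ug/mL

In this assay compound 2 gives the lowest number of the three. Compound 1 and compound 3 sit at one and the same higher number, and the gap from compound 2 to each of them lies beyond the scatter. Within the data shown here, no two measured compounds differ in one place only, so no single measured step can be taken as a reference; compound 1 and compound 3 show only that other substitutions on the shared core return weaker inhibition than compound 2.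

Compound 4, `c1ccc(N2CCN(c3nc(-n4ccc5ccccc54)c4ccccc4n3)CC2)cc1`, is not yet measured. Its change relative to compound 2 is phenyl in place of hydrogen on an amine nitrogen in a ring. Among the measured compounds shown here, with no measured step of this kind available, the expectation rests on compound 2 alone as the anchor and on the fact that the two other variants return higher numbers. The step from compound 2 to compound 4 is expected to be moderate, in the direction of a higher number, a 2.4-fold higher number from compound 2 to compound 4 (0.39 log units; beyond the scatter), though a result within the scatter cannot be ruled out.

For compound 4 the estimated value in this assay is 20 ug/mL, with a range from 6 ug/mL to 50 ug/mL.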

Compound 4, half-maximal inhibitory concentration: 50 ug/mL
Estimate against measurement, compound 4: 2.5-fold (0.40 log units) below; the measured number falls inside the stated range.
By their numbers in this assay, from the lowest: compound 2; then compounds 1, 3 and 4 (each within the scatter of the next).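

In this assay the series now has its first step in one place only, a 6.1-fold higher number from compound 2 to compound 4 (0.79 log units; beyond the scatter), for phenyl in place of hydrogen on an amine nitrogen in a ring. This shows that the position is not indifferent to substitution: with the rest of compound 2 unchanged, this change alone moves the read-out beyond the scatter, towards weaker inhibition. The data at hand give no measured basis for assigning a reason to this step.

As far as these compounds go, it remains open whether the higher number is specific to phenyl or follows from any replacement of this hydrogen, and a benzyl or an acetyl group on the same nitrogen would bear directly on that. Also open, from the compounds shown here alone, is whether phenyl in place of hydrogen gives a step of similar size on the core of compound 1, where the same amine nitrogen carries hydrogen.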